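Bis-pyrazinylmethyl ether of a cinnamamide phenol

This account rests on a few compounds, and the source may have more. Where it says the series, first, only, none or still open, it means among the compounds named here.

Measured so far:
compound 1, `COc1cc(CNC(=O)/C=C/c2cccc(OCc3nc(C)c(C)nc3C)c2)ccc1OCc1nc(C)c(C)nc1C` — 8700 nM
compound 2, `COc1cc(CNC(=O)/C=C/c2ccc(OC)c(OCc3nc(C)c(C)nc3C)c2)ccc1O` — 9250 nM
compound 3, `COc1ccc(/C=C/C(=O)NCc2ccc(OCc3nc(C)c(C)nc3C)c(OC)c2)cc1O` — 8560 nM

In a functional assay on SH-SY5Y cells (Homo sapiens) for cytotoxicity, read by MTT assay, with stated times of 24 h and 4 h (on this read-out higher numbers stand for an effect only at larger amounts of compound and lower numbers for an effect already at smaller amounts), compound 3 gives the lowest of the three numbers, but its gaps to compound 1 and to compound 2 lie within the scatter, so the three stand level. Compound 4, `COc1cc(CNC(=O)/C=C/c2ccc(OC)c(OCc3nc(C)c(C)nc3C)c2)ccc1OCc1nc(C)c(C)nc1C`, differs from compound 3 by (3,5,6-trimethylpyrazin-2-yl)methyl in place of hydrogen on an oxygen on an aromatic ring. Within the data shown here, no pair among the measured compounds isolates this change, and compound 1, which carries two such ethers, sits at the same level as compound 2 with a free hydroxy, so no step beyond the scatter is expected for a 1.0-fold higher number from compound 3 to compound 4 (0.01 log units; within the scatter). Compound 4 is therefore estimated at 8800 nM, with a range from 4500 nM to 17000 nM in this assay.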

Compound 4, half-maximal effective concentration: 11600 nM
Compound 4: middle estimate off by 1.3-fold (0.12 log units), on the low side; the measured number falls inside the stated range.
By their numbers in this assay, from the lowest: compounds 3, 1, 2 and 4 (each within the scatter of the next).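

In this assay, (3,5,6-trimethylpyrazin-2-yl)methyl in place of hydrogen on an oxygen on an aromatic ring gives a 1.4-fold higher number from compound 3 to compound 4 (0.13 log units; within the scatter) and a 1.3-fold higher number from compound 2 to compound 4 (0.10 log units; within the scatter) on two different oxygens, while methoxy in place of hydrogen on an aromatic carbon gives a 1.3-fold higher number from compound 1 to compound 4 (0.12 log units; within the scatter) in the series. All three steps lie within the scatter, so neither ether nor methoxy shifts the number at these places. No measurement shown offers any explanation for this flatness. The compounds shown leave open whether an amine or a carboxylic acid in place of the (3,5,6-trimethylpyrazin-2-yl)methyl group would move the number beyond the scatter.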